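This account rests on a few compounds, and the source may have more. Where it says the series, first, only, none or still open, it means among the compounds named here.

Compound 1 `CC(C)(C)c1ccc(CN2C(=O)S/C(=C\c3cccc(N)c3)C2=O)cc1`, compound 2 `Cc1ccc(CN2C(=O)S/C(=C\c3cccc(N)c3)C2=O)cc1` and compound 3 `Cc1ccc(CN2C(=O)S/C(=C\c3ccc(N)cc3)C2=O)cc1` share one core and differ at two places. In a functional assay on L1210 cells (Mus musculus) for cytotoxicity, read by cell counting, with a stated time of 2 days (on this read-out lower numbers stand for stronger inhibition and higher numbers for weaker inhibition), compound 1 gives 223000 nM, compound 2 gives 176000 nM and compound 3 gives 94000 nM. Compound 2 holds the second highest of the three numbers; its nearest neighbour is compound 1 and its furthest is compound 3, and both steps, a 1.3-fold lower number from compound 1 to compound 2 (0.10 log units; within the scatter) and a 1.9-fold lower number from compound 2 to compound 3 (0.27 log units; within the scatter), stay within the scatter, so no ordering among the three can be read from them. Compound 4 `Nc1cccc(/C=C2\SC(=O)N(Cc3ccc(Cl)cc3)C2=O)c1` is not yet measured. It differs from compound 2 by chloro in place of methyl on an aromatic carbon, the same place at which compound 1 and compound 2 differ. Going by the values given here, only the step from compound 1 to compound 2 bears on this change, and it stayed within the scatter; no measured compound carries chloro at this place. A step of no more than scatter size in this assay is therefore expected, and the expected step is a 1.0-fold lower number from compound 2 to compound 4 (0.02 log units; within the scatter). For compound 4 the estimate is 170000 nM, with a range from 60000 nM to 480000 nM.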

Compound 4, half-maximal inhibitory concentration: 218000 nM
Beside the measured number, compound 4's estimate is 1.3-fold (0.11 log units) below it, and the stated range covers the measured number.
By their numbers in this assay, from the lowest: compounds 3, 2, 4 and 1 (each within the scatter of the next, the first and the last beyond it).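

In this assay, chloro in place of methyl gives a 1.2-fold higher number from compound 2 to compound 4 (0.09 log units; within the scatter) at this place, and chloro in place of tert-butyl gives a 1.0-fold lower number from compound 1 to compound 4 (0.01 log units; within the scatter) at the same place, so chloro, methyl and tert-butyl on this aromatic carbon, para to a large group, cannot be told apart. The earlier compounds shown here carried only carbon groups here; compound 4 shows that a chlorine atom at this place also gives no step beyond the scatter. Nothing at hand accounts for this result.

As far as these compounds go, whether a methoxy group, an amine or a carboxylic acid at this place would give a step beyond the scatter stays open. Also open, from the compounds shown here alone, is whether chloro gives the same result when combined with the 4-aminophenyl group of compound 3.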